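Adding a dimethylamino group to the compound with the lower of two numbers

The source may hold more compounds than are shown below. What is called first, only, known or untested is meant among the compounds shown, and "the series" means these compounds.

Measured so far:
- compound 1, `CN(C)c1nsc(-c2ccc(N3CCN(c4cccc(C(F)(F)F)c4)CC3)nn2)n1`: 39%
- compound 2, `FC(F)(F)c1cc(N2CCN(c3ccc(-c4ncns4)nn3)CC2)cc(C(F)(F)F)c1`: 24%

Both were tested in a functional assay on the whole organism (lung) for inhibition, with Mus musculus as the target, with a stated time of 28 days, at a dose of 15 mg/kg by the oral route; on this read-out higher numbers stand for more inhibition at the one dose given (going by the name of the read-out) and lower numbers for less inhibition. Compound 2 stands lowest of the two numbers; its nearest neighbour, compound 1, lies higher by a margin beyond the usual scatter. The two compounds differ in more than one place, so the gap between them cannot be pinned on a single change.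

Compound 3, `CN(C)c1nsc(-c2ccc(N3CCN(c4cc(C(F)(F)F)cc(C(F)(F)F)c4)CC3)nn2)n1`, has not been measured yet. It differs from compound 2 in one place: dimethylamino in place of hydrogen on an aromatic carbon. This is the same dimethylamino group that compound 1 carries, and compound 1 gives 39% in this assay. On that basis the step of a number 9 percentage points higher from compound 2 to compound 3 (within the scatter) is expected to be a moderate rise, though the second trifluoromethyl group kept from compound 2 leaves the outcome uncertain. Compound 3 is therefore estimated at 33%, with a likely range from 18% to 48%.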

Compound 3, a percentage reported as inhibition, in the whole organism at one dose (the size of the read-out at that dose, not a potency): 13%
The estimate for compound 3 lay 20 percentage points above the measured number; measured number outside the range, below it.
By their numbers in this assay, from the lowest: compound 3; then compound 2; then compound 1.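

In this assay, dimethylamino in place of hydrogen on the aromatic carbon between two ring nitrogen atoms gives a number 11 percentage points lower from compound 2 to compound 3 (beyond the scatter), so with two trifluoromethyl groups on the far end of the molecule, this change goes with less inhibition. With dimethylamino held in place, trifluoromethyl in place of hydrogen on an aromatic carbon gives a number 26 percentage points lower from compound 1 to compound 3 (beyond the scatter), so adding the second trifluoromethyl group also goes with less inhibition. Nothing measured here explains either drop.

The compounds shown leave open how dimethylamino compares with hydrogen at this carbon when only one trifluoromethyl group is present. They also leave open whether a smaller amine such as methylamino, or a methoxy group, would fare differently at this carbon.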